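The source may report more compounds than this note shows. Statements on the series, on what has been measured and on what is new or still open speak of the compounds shown alone.

Measured in a functional assay on the whole organism (strain Sprague-Dawley) for inhibition, with Rattus norvegicus as the target, with a stated time of 10 min; on this read-out higher numbers stand for an effect only at larger amounts of compound and lower numbers for an effect already at smaller amounts:
Compound 1 `CCOc1ccc(S(=O)(=O)N(CC)CC)cc1-c1ncc(C(=O)O)c(=O)[nH]1`: 40 mg/kg
Compound 2 `CCOC(=O)c1cnc(-c2cc(N)ccc2OCC)[nH]c1=O`: 0.5 mg/kg
Compound 3 `CCOC(=O)C(=O)Nc1ccc(OCC)c(-c2ncc(C(=O)OCC)c(=O)[nH]2)c1`: 5 mg/kg

Compound 3 stands second highest of these three numbers, above compound 2 and below compound 1. Compound 4 `CCOC(=O)c1cnc(-c2cc(S(=O)(=O)N(CC)CC)ccc2OCC)[nH]c1=O` has not yet been measured. Its difference from compound 3 is diethylsulfamoyl in place of ((ethoxycarbonyl)carbonyl)amino on an aromatic carbon. For the measured compounds named here, only one measured step bears on this place: a 10-fold higher number from compound 2 to compound 3 (1.00 log units; beyond the scatter), which concerns the leaving group alone. Going by the values given here, no measured step isolates the entering group. Compound 1 carries diethylsulfamoyl but differs from compound 4 elsewhere. Compound 1 gives 40 mg/kg, so a modest rise in the number is expected in this assay. The expected change is a 2.4-fold higher number from compound 3 to compound 4 (0.38 log units; beyond the scatter). For compound 4 the estimated value is 12 mg/kg, with an expected range from 3 mg/kg to 40 mg/kg.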

Compound 4, dose for 50% inhibition: 10 mg/kg
For compound 4 the middle estimate is 1.2-fold (0.08 log units) above the measured one; measured number inside the range.
By their numbers in this assay, from the lowest: compound 2; then compounds 3 and 4 (each within the scatter of the next); then compound 1.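

In this assay, exchanging ((ethoxycarbonyl)carbonyl)amino for diethylsulfamoyl on this aromatic carbon gives a 2.0-fold higher number from compound 3 to compound 4 (0.30 log units; within the scatter), so these two large groups cannot be told apart here, whereas the plain amino group remains clearly separate, with a 20-fold higher number from compound 2 to compound 4 (1.30 log units; beyond the scatter). With diethylsulfamoyl held constant, the other end of the molecule also matters, as the ethyl on the oxygen next to the carbonyl group gives a 4.0-fold lower number from compound 1 to compound 4 (0.60 log units; beyond the scatter). No available evidence accounts for these steps. Going by these compounds, it remains open whether a methylamino or acetylamino group at this carbon would read like amino or like the two larger groups.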